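Notes on the series: bromo in place of fluoro

A few compounds are considered here, and "the series" means these few. Any claim that something is new, unique, unknown or untested is made for them only; others in the source may bear on it.

Measured in an ADME assay on HEK293 cells (Homo sapiens) for inhibition, read by MTT assay, with a stated time of 3 days; a lower number here means a stronger inhibitor, a higher number a weaker inhibitor:
compound 1 `C/C=C/COc1cc(/C=C\c2cc(OC)c(OC)c(OC)c2)ccc1OC`: 135000 nM
compound 2 `COCOc1cccc(/C=C/CCCOc2cc(/C=C\c3cc(OC)c(OC)c(OC)c3)ccc2OC)c1`: 30000 nM
compound 3 `COc1ccc(/C=C\c2cc(OC)c(OC)c(OC)c2)cc1OCCC/C=C/c1ccc(F)cc1`: 115000 nM

Compound 3 stands at 115000 nM in this assay, within the scatter of compound 1 and with a higher number than compound 2. The next compound, compound 4 `COc1ccc(/C=C\c2cc(OC)c(OC)c(OC)c2)cc1OCCC/C=C/c1ccc(Br)cc1`, differs from compound 3 as follows: bromo in place of fluoro on an aromatic carbon. In short, it has bromo in place of fluoro on an aromatic carbon, para to a large group.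

For the measured compounds named here, no measured step exchanges one halogen for another, so the evidence is indirect. Where 4-fluorophenyl stands in place of 3-(methoxymethoxy)phenyl, the result is a 3.8-fold higher number from compound 2 to compound 3 (0.58 log units; beyond the scatter), a modest step. Where 4-(4-fluorophenyl)but-3-en-1-yl stands in place of prop-1-en-1-yl, the result is a 1.2-fold lower number from compound 1 to compound 3 (0.07 log units; within the scatter). Given these two steps, no change beyond the scatter is expected for the smaller exchange here, with at most a slight lean towards a lower number. The expected step is a 1.2-fold lower number from compound 3 to compound 4 (0.08 log units; within the scatter). For compound 4 the estimated value is 95000 nM, with an expected range from 40000 nM to 170000 nM.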

Compound 4, half-maximal inhibitory concentration: 55000 nM
For compound 4 the middle estimate is 1.7-fold (0.24 log units) above the measured one, within the range that was stated.
By their numbers in this assay, from the lowest: compounds 2 and 4 (each within the scatter of the next); then compounds 3 and 1 (each within the scatter of the next).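

In this assay, for the compounds shown here, the exchange of fluoro for bromo on an aromatic carbon, para to a large group, gives the first direct reading of the halogen at this position, a modest step beyond the scatter (a 2.1-fold lower number from compound 3 to compound 4 (0.32 log units; beyond the scatter)). With bromo, the chain also changes its standing against the other two compounds: it lies within the scatter of the 3-(methoxymethoxy)phenyl analogue (a 1.8-fold higher number from compound 2 to compound 4 (0.26 log units; within the scatter)) and now separates from the short prop-1-en-1-yl ether (a 2.5-fold lower number from compound 1 to compound 4 (0.39 log units; beyond the scatter)), whereas the 4-fluorophenyl chain of compound 3 did the reverse on both counts. Nothing available explains the halogen step.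

On these data alone, this rests on a single pair of halogens, so it remains open whether chloro or iodo on the same aromatic carbon would fit between or beyond them. Also open, as far as these compounds go, is how an amine or a carboxylic acid there would read in this assay.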